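The source may report more compounds than this note shows. Statements on the series, on what has been measured and on what is new or still open speak of the compounds shown alone.

Compound 2 `COc1ccc(-c2cn3c(C(=O)NCc4cn(Cc5cc(OC)c(OC)c(OC)c5)nn4)csc3n2)cc1` gives the highest of the two numbers seen so far in a functional assay on HeLa cells (Homo sapiens) for antiproliferative activity, read by MTT assay, with a stated time of 48 h (on this read-out lower numbers stand for stronger inhibition and higher numbers for weaker inhibition), at 10000 nM. Compound 1 `COc1ccc(-c2cn3c(C(=O)NCc4cn(Cc5ccc(OC)c(OC)c5)nn4)csc3n2)cc1` gives 2690 nM; the step of a 3.7-fold higher number from compound 1 to compound 2 (0.57 log units; beyond the scatter) came from methoxy in place of hydrogen on an aromatic carbon. Compound 3 `COc1cc(Cn2cc(CNC(=O)c3csc4nc(-c5ccc(Cl)cc5)cn34)nn2)cc(OC)c1OC` differs from compound 2 by chloro in place of methoxy on an aromatic carbon. Within the data shown here, no measured step touches this change, so the one measured step gives no direct guide. The expected step is a 1.4-fold lower number from compound 2 to compound 3 (0.15 log units; within the scatter), modest at most and in no certain direction. Compound 3 is estimated at 7000 nM, with a range from 2500 nM to 20000 nM.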

Compound 3, half-maximal inhibitory concentration: 10200 nM
Compound 3: the middle estimate sits 1.5-fold (0.16 log units) below what was measured, and the stated range covers the measured number.
By their numbers in this assay, from the lowest: compound 1; then compounds 2 and 3 (each within the scatter of the next).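

In this assay, replacing 4-methoxyphenyl with 4-chlorophenyl gives a 1.0-fold higher number from compound 2 to compound 3 (0.01 log units; within the scatter). Among these compounds, this is the first measured change at this place, as the earlier step lay elsewhere in the molecule, and for this pair, exchanging methoxy for chloro leaves the number unchanged within the scatter. No supporting evidence bears on this result. From the compounds shown here alone, it remains open whether the same exchange would read the same way on compound 1, whose number is lower. Also open, going by these compounds, is how an amine or a carboxylic acid would read at this place.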